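From Chlorophenyl to Trifluoromethylphenyl on the Ring Nitrogen

A few compounds are considered here, and "the series" means these few. Any claim that something is new, unique, unknown or untested is made for them only; others in the source may bear on it.

Of the compounds shown here, three sharing one core have been tested in a functional assay on MCF7 cells (Homo sapiens) for cytotoxicity, read by MTT assay, with a stated time of 48 h; on this read-out lower numbers stand for stronger inhibition and higher numbers for weaker inhibition. Compound 1 `CC(C)=CCC/C(C)=C/CC/C(C)=C/CC[C@@H]1[C@@]2(C)CCC(=O)C(C)(C)[C@@H]2CC[C@@]1(C)O`, whose core bears a carbonyl, gives 16200 nM. Compound 2 `CC(C)=CCC/C(C)=C/CC/C(C)=C/CC[C@@H]1[C@@]2(C)CC/C(=N\OCc3cn(-c4ccc(F)cc4)nn3)C(C)(C)[C@@H]2CC[C@@]1(C)O`, where an oxime ether carries a fluoro-substituted aromatic ring, gives 26000 nM, and compound 3 `CC(C)=CCC/C(C)=C/CC/C(C)=C/CC[C@@H]1[C@@]2(C)CC/C(=N\OCc3cn(-c4ccc(Cl)cc4)nn3)C(C)(C)[C@@H]2CC[C@@]1(C)O`, which carries chloro in place of fluoro on an aromatic carbon, gives 12400 nM. That single swap produced a 2.1-fold lower number from compound 2 to compound 3 (0.32 log units; beyond the scatter). Compound 3 thus shows the lowest number of the three; compound 1 sits within the scatter of it, while compound 2 lies beyond the scatter.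

Compound 4 `CC(C)=CCC/C(C)=C/CC/C(C)=C/CC[C@@H]1[C@@]2(C)CC/C(=N\OCc3cn(-c4cccc(C(F)(F)F)c4)nn3)C(C)(C)[C@@H]2CC[C@@]1(C)O` is the next step: 3-(trifluoromethyl)phenyl in place of 4-chlorophenyl on an aromatic nitrogen. Going by the values given here, the only measured step that bears on this change is the modest halogen swap between compound 2 and compound 3, and no measured pair involves a trifluoromethyl group. The step is therefore expected to be small, a 1.0-fold lower number from compound 3 to compound 4 (0.01 log units; within the scatter), within the scatter in either direction. Compound 4 is estimated at 12000 nM, with a likely range from 6000 nM to 25000 nM in this assay.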

Compound 4, half-maximal inhibitory concentration: 21400 nM
Estimate against measurement, compound 4: 1.8-fold (0.25 log units) below; the range from low to high includes it.
By their numbers in this assay, from the lowest: compounds 3, 1, 4 and 2 (each within the scatter of the next, the first and the last beyond it).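

In this assay the ring nitrogen accepts a bulkier aryl group without a clear shift: 3-(trifluoromethyl)phenyl has 10 heavy atoms against 7 in 4-chlorophenyl, yet the swap gives a 1.7-fold higher number from compound 3 to compound 4 (0.24 log units; within the scatter). Set against the fluoro analogue, it gives a 1.2-fold lower number from compound 2 to compound 4 (0.08 log units; within the scatter), so compound 4 cannot be told apart from either halogen compound, even though those two differ beyond the scatter from each other. Nothing shown here gives a reason for these numbers.

Because the group and its place on the phenyl ring change together, the compounds shown cannot separate the two effects; 3-chlorophenyl or 4-(trifluoromethyl)phenyl would be needed for that. Also open, from the compounds shown here alone, is how an amine or a carboxylic acid on that phenyl ring would read.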